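A few compounds are considered here, and "the series" means these few. Any claim that something is new, unique, unknown or untested is made for them only; others in the source may bear on it.

Compound 1, `COC(=O)C1(c2ccc([N+](=O)[O-])cc2)CC1CN1CCN(c2ccccn2)CC1`, and compound 2, `COC(=O)C1(c2ccc(Cl)cc2)CC1CN1CCN(c2ccccn2)CC1`, share one core and differ only in the group on the aromatic carbon. In an assay for displacement of a labelled ligand from Sigma non-opioid intracellular receptor 1 (Cavia porcellus) (on this read-out higher numbers stand for weaker inhibition and lower numbers for stronger inhibition), compound 1 gives 769 nM, and compound 2 gives 707 nM. The step of a 1.1-fold lower number from compound 1 to compound 2 (0.04 log units; within the scatter) shows that the two numbers sit within the scatter of each other, so neither compound can be called stronger or weaker on this assay; compound 2 simply stands with the smaller of the two numbers, compound 1 nearest to it.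

Compound 3, `COC(=O)C1(c2ccc(C)cc2)CC1CN1CCN(c2ccccn2)CC1`, has not yet been measured in this assay. It differs from compound 2 by methyl in place of chloro on an aromatic carbon. Among the measured compounds shown here, the only measured step that bears on this change is the one from compound 1 to compound 2, where a chloro replaced a nitro at the same aromatic carbon and the number stayed within the scatter. One exchange of a single-atom group at that position has thus left the read-out essentially unmoved, and a further exchange of that group for methyl is expected to do the same, with a 1.1-fold higher number from compound 2 to compound 3 (0.03 log units; within the scatter) expected to stay within the scatter. Compound 3 is therefore estimated at 750 nM, with a range from 350 nM to 1600 nM.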

Compound 3, inhibition constant: 497 nM
Estimate against measurement, compound 3: 1.5-fold (0.18 log units) above; the range from low to high includes it.
By their numbers in this assay, from the lowest: compounds 3, 2 and 1 (each within the scatter of the next).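

In this assay the exchange of chloro for methyl gives a 1.4-fold lower number from compound 2 to compound 3 (0.15 log units; within the scatter) and the exchange of nitro for methyl gives a 1.5-fold lower number from compound 1 to compound 3 (0.19 log units; within the scatter) so both new steps stay inside the usual spread of repeat measurements. The earlier compounds shown here showed this for a single pair of groups, nitro and chloro, whereas compound 3 extends it to three groups, and no pair among nitro, chloro and methyl on this aromatic carbon, para to a large group, is told apart by this read-out. The methyl also brings a carbon atom to this place in the exchange of 4-chlorophenyl to 4-methylphenyl, and the number still cannot be separated from those of the other two compounds, while nothing at hand offers an explanation for this flat picture.

From the compounds shown here alone, whether this tolerance holds for an amine, a carboxylic acid or a longer chain such as butyl on the same aromatic carbon remains open, since none of these appears among the three compounds. Going by these compounds, it is also open whether changes elsewhere on the shared core, such as replacing the methyl ester with a carboxylic acid or an amide, would move the number beyond the scatter.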